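Trifluoromethoxy Urea on the Shared Core of Compound 3

The compounds below may be only part of what the source reports. "The series", "measured", "known", "first", "only" and "open" are said of these compounds alone.

Compound 3 `CC(C)c1ccc(NC(=O)N2CCN(c3nncc4ccccc34)CC2)cc1` carries an isopropyl group on its aryl urea and the same core as compound 2. In an assay on HEK293 cells for inhibition of transient receptor potential cation channel subfamily V member 1 (Homo sapiens), read by FLIPR (on this read-out lower numbers stand for stronger inhibition and higher numbers for weaker inhibition), compound 3 reaches only a limit of the assay, > 10000 nM. Compound 2 `CC(C)(C)c1ccc(NC(=O)N2CCN(c3nncc4ccccc34)CC2)cc1` differs from compound 3 by one methyl on a saturated chain carbon. In this assay compound 2 likewise gives a limit, > 10000 nM. The step between them is a step that the two limits leave unreadable from compound 2 to compound 3. Compound 1 `Cc1cc(N2CCN(C(=O)Nc3ccc(OC(F)(F)F)cc3)CC2)nnc1Cl` places the trifluoromethoxy aryl urea on a different core. In this assay compound 1 also gives a limit, > 10000 nM. Every measured value thus sits at the limit of > 10000 nM in this assay, at which 3 of the 3 values shown sit, and no readable step exists anywhere in the set.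

Compound 4 `O=C(Nc1ccc(OC(F)(F)F)cc1)N1CCN(c2nncc3ccccc23)CC1` differs from compound 3 by trifluoromethoxy in place of isopropyl on an aromatic carbon. Among the measured compounds shown here, no measured step touches this exchange, and the one step that is measured, from compound 2 to compound 3, cannot be read. For the measured compounds named here, the only guidance is compound 1, whose limit, > 10000 nM, was obtained with the entering trifluoromethoxy group on another core. Compound 4 is therefore expected to remain at the limit, with an estimated 15000 nM ranging from 4000 nM to 60000 nM. The step implied by this estimate, a step that the limit leaves unreadable from compound 3 to compound 4, is expected to be none beyond the scatter.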

Compound 4, half-maximal inhibitory concentration: > 10000 nM
Compound 4 gave a limit, no number; the forecaster's own chance of this, stated with the estimate: 75%; the middle value is on the limit's open side.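

Compound 4 gives > 10000 nM in this assay as a limit, not a number. Its steps from compound 1, compound 2 and compound 3 cannot be read, and all four compounds share one boundary: the limit of > 10000 nM in this assay, at which 4 of the 4 values shown sit. The compounds shown leave open how large the exchange of isopropyl for trifluoromethoxy is and whether either core gives a readable value in this assay at all.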